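The source may hold more compounds than are shown below. What is called first, only, known or untested is meant among the compounds shown, and "the series" means these compounds.

Of the compounds shown here, three built on one shared core have been tested in a functional assay on PANC-1 cells (Homo sapiens) for inhibition, read by MTT assay, with a stated time of 24 h, tested at 10 uM; on this read-out higher numbers stand for more inhibition at the one concentration tested (going by the name of the read-out) and lower numbers for less inhibition. Compound 1, `CC(C)=CCC/C(C)=C/CC1Cc2c(OCCCNC(=O)c3ccco3)cc(=O)n(CCCO)c2CC1(C)C`, gives 2.8%. Compound 2, `CC(C)=CCC/C(C)=C/CC1Cc2c(OCCCNC(=O)c3ccc([N+](=O)[O-])cc3)cc(=O)n(CCCO)c2CC1(C)C`, gives 6.5%. Compound 3, `COc1ccc(OCCCOc2cc(=O)n(CCCO)c3c2CC(C/C=C(\C)CCC=C(C)C)C(C)(C)C3)cc1`, gives 0%. Compound 3 thus stands at the bottom of the three numbers, yet it is not separated from the others: the step of a number 2.8 percentage points lower from compound 1 to compound 3 (within the scatter) and the step of a number 6.5 percentage points lower from compound 2 to compound 3 (within the scatter) are both within the scatter, so all three compounds are, for practical purposes, alike in this assay.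

Compound 4, `CC(C)=CCC/C(C)=C/CC1Cc2c(OCCCOc3ccc(Cl)cc3)cc(=O)n(CCCO)c2CC1(C)C`, is the next compound to be measured. It differs from compound 3 in one place: chloro in place of methoxy on an aromatic carbon.

Among the measured compounds shown here, none of the measured steps touches this particular spot. The step of a number 3.7 percentage points higher from compound 1 to compound 2 (within the scatter) exchanges one aromatic group for another at a carbonyl carbon, and the steps of a number 2.8 percentage points lower from compound 1 to compound 3 (within the scatter) and a number 6.5 percentage points lower from compound 2 to compound 3 (within the scatter) swap a whole side chain. All three stay within the scatter, which suggests that changes at the far end of the side chain have so far moved this assay little. The expectation is therefore a step of a number 3 percentage points higher from compound 3 to compound 4 (within the scatter) that stays within the scatter. Compound 4 is estimated to give 3%, within a range from 0% to 12%.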

Compound 4, a percentage reported as inhibition, at one concentration (the size of the read-out at that concentration, not a potency): 0%
The estimate for compound 4 lay 3 percentage points above the measured number; the range from low to high includes it.
By their numbers in this assay, from the lowest: compounds 3, 4, 1 and 2 (each within the scatter of the next).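

Methoxy and chloro, on an aromatic carbon para to a large group, give the same printed number in this assay, with no change at the digits printed from compound 3 to compound 4 (within the scatter) as the step, so this is the first direct sign that the group at this spot need not alter the reading, at least for this one pair. The wider comparisons with the amide side chains agree with what the methoxy compound showed: the change to 4-chlorophenoxy gives a number 2.8 percentage points lower from compound 1 to compound 4 (within the scatter) and a number 6.5 percentage points lower from compound 2 to compound 4 (within the scatter), so neither phenoxy group sets itself apart from those amides in this assay. No other measurement is available to bear on this result.

Among the compounds shown here, with only two groups compared at this aromatic carbon, it remains open whether an amine or a carboxylic acid there would give a number that stands clear of the scatter. From the compounds shown here alone, it is equally open whether a longer chain joining the phenoxy group to the shared core, or a change elsewhere on that core, would separate any compound from the others in this assay at all.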